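Para substituent variation in a boron-containing series

This account rests on a few compounds, and the source may have more. Where it says the series, first, only, none or still open, it means among the compounds named here.

Measured compounds:
compound 1, `Fc1ccc([B-]2(c3ccccc3)[NH2+]CCO2)cc1`: 33600 nM
compound 2, `CCCCc1ccc([B-]2(c3ccccc3)[NH2+]CCO2)cc1`: 12100 nM

Going by the values given here, only two compounds carry numbers. In an assay on HEK293 cells for inhibition of transient receptor potential cation channel subfamily V member 6 (Homo sapiens), read by FLIPR, with a stated time of 5 min (a higher number here means a weaker inhibitor, a lower number a stronger inhibitor), compound 1 gives 33600 nM, while compound 2 gives 12100 nM. Among the compounds with values here, the one measured step, a 2.8-fold lower number from compound 1 to compound 2 (0.44 log units; beyond the scatter), is the sole point of reference. Compound 2 therefore stands at the lower of the two numbers, set apart from compound 1 by that step.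

Compound 3, `c1ccc(-c2ccc([B-]3(c4ccccc4)[NH2+]CCO3)cc2)cc1`, has not been measured in this assay. It differs from compound 2 by phenyl in place of butyl on an aromatic carbon: the group sits on an aromatic carbon of a six-membered aromatic ring of carbon only, para to a large group, the same place where butyl replaced fluoro in the measured step. Within the data shown here, that step lowered the number modestly and lies beyond the scatter; it is the only one bearing on this change. Among the measured compounds shown here, a phenyl at the same place is a larger group than butyl, but no measured pair shows what a second ring there does.

A further small shift to a lower number, or none beyond the scatter, is the expected outcome; compound 3 is estimated at 7000 nM, in the range 2500 nM to 20000 nM, an expected step of a 1.7-fold lower number from compound 2 to compound 3 (0.24 log units; within the scatter).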

Compound 3, half-maximal inhibitory concentration: 51300 nM
Beside the measured number, compound 3's estimate is 7.3-fold (0.87 log units) below it; measured number above the stated range.
By their numbers in this assay, from the lowest: compound 2; then compounds 1 and 3 (each within the scatter of the next).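

Working notes on the position para to the large group: in this assay the lower number seen with butyl does not carry over to phenyl at this aromatic carbon (a 4.2-fold higher number from compound 2 to compound 3 (0.63 log units; beyond the scatter)), so the earlier step from fluoro to butyl gives no general direction for carbon groups placed here. Phenyl and fluoro cannot be separated at this position (a 1.5-fold higher number from compound 1 to compound 3 (0.18 log units; within the scatter)), which leaves compound 2, with its butyl chain, as the only one of the three whose steps to both others lie beyond the scatter. Nothing available bears on why the open chain and the added aromatic ring differ in this way.

Three compounds do not show whether the lower number depends on the chain itself, and a propyl group, a longer chain such as hexyl, or a branched tert-butyl group at the same carbon would test that directly. As far as these compounds go, the response to a group carrying a heteroatom, such as an amine, a methoxy group or a carboxylic acid, also remains open, as does the effect of any change to the second phenyl ring or to the shared core.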